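The source may report more compounds than this note shows. Statements on the series, on what has been measured and on what is new or still open speak of the compounds shown alone.

Compound 1 `Cc1nn(C)c(Oc2cccc(F)c2)c1/C=N\CCCCCOc1cc2oc(=O)cc(C)c2cc1Cl`: in a functional assay on U-87MG ATCC cells for antiproliferative activity against U-87 MG (Homo sapiens), read by MTT assay, with a stated time of 72 h (a higher number here means a weaker inhibitor, a lower number a stronger inhibitor), compound 1 gives 9870 nM.
Compound 2 `Cc1nn(C)c(Oc2ccc(I)cc2)c1/C=N\CCCCCOc1cc2oc(=O)cc(C)c2cc1Cl`: in this assay compound 2 reaches only the assay limit, > 25000 nM.
Compound 3 `Cc1nn(C)c(Oc2ccc(F)c(F)c2)c1/C=N\CCCCCCOc1cc2oc(=O)cc(C)c2cc1Cl`: in this assay compound 3 likewise reaches only the assay limit, > 25000 nM.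

Compound 3 therefore stands at the limit (the limit of > 25000 nM in this assay, at which 2 of the 3 values shown sit), with no number of its own. Compound 4 `Cc1nn(C)c(Oc2ccc(OC(F)(F)F)cc2)c1/C=N\CCCCCCOc1cc2oc(=O)cc(C)c2cc1Cl` differs from it in one place: 4-(trifluoromethoxy)phenyl in place of 3,4-difluorophenyl on an oxygen on an aromatic ring. Within the data shown here, the only measured step at that place, an at least 2.5-fold higher number from compound 1 to compound 2 (0.40 log units; beyond the scatter), weakened the compound; it starts from a measured number and swaps a different pair of groups, so it bears on compound 4 only loosely. Compound 3 offers nothing to move from, and weakening or no change beyond the scatter is the expected outcome. Compound 4 is therefore expected to stay at the limit, estimated at 30000 nM (range 8000 nM to 80000 nM), a step that the limit leaves unreadable from compound 3 to compound 4.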

Compound 4, half-maximal inhibitory concentration: 9620 nM
For compound 4 the middle estimate is 3.1-fold (0.49 log units) above the measured one; measured number inside the range.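

At this place, on an oxygen on an aromatic ring, a change of group can also strengthen a compound: 4-(trifluoromethoxy)phenyl in place of 3,4-difluorophenyl gives an at least 2.5-fold lower number from compound 3 to compound 4 (0.41 log units; beyond the scatter) in this assay, whereas the earlier step here went the other way. The size of this gain is only a bound, because compound 3 has no number of its own: the limit of > 25000 nM in this assay, at which 2 of the 4 values shown sit.

On these data alone, whether the gain comes from the trifluoromethoxy group itself stays open, as does how an unsubstituted phenyl, or a phenyl carrying an amine or a carboxylic acid, would behave here. As far as these compounds go, whether 4-(trifluoromethoxy)phenyl would act the same way on the chain of compound 1 is also open.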